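Nitro for Hydroxy on Two Related Benzothiazole-Free Cores

The compounds below may be only part of what the source reports. "The series", "measured", "known", "first", "only" and "open" are said of these compounds alone.

Of the compounds shown here, three have been measured in a functional assay on A549 cells (Homo sapiens) for antiproliferative activity, read by sulforhodamine B assay, with a stated time of 48 h; a higher number here means a weaker inhibitor, a lower number a stronger inhibitor. Compound 1 `COc1cc(OC)c2sc(-c3ccc(N/C=C\C(=O)c4ccc(OC)c(O)c4)c(C)c3)nc2c1` gives 14300 nM in this assay. Compound 2 `COc1cc(OC)c2sc(-c3ccc(N/C=C\C(=O)c4ccc(OC)c([N+](=O)[O-])c4)c(C)c3)nc2c1` differs from compound 1 by one change, (nitro in place of hydroxy on an aromatic carbon); in this assay compound 2 gives 12100 nM, so the step of a 1.2-fold lower number from compound 1 to compound 2 (0.07 log units; within the scatter) is small. Compound 3 `COc1ccc2nc(-c3ccc(N/C=C\C(=O)c4ccc(OC)c(O)c4)cc3)sc2c1` carries a different core; the difference between the core of compound 3 and the core of compound 1 is not broken down here. Compound 3 gives 12800 nM in this assay, a number that stands close to those of compound 1 and compound 2.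

Compound 4 `COc1ccc2nc(-c3ccc(N/C=C\C(=O)c4ccc(OC)c([N+](=O)[O-])c4)cc3)sc2c1` has not yet been measured. It is made from compound 3 by nitro in place of hydroxy on an aromatic carbon, the same change that turns compound 1 into compound 2, made at a place described in the same words: on an aromatic carbon of a six-membered aromatic ring of carbon only, ortho to a methoxy group, meta to a large group. Because that earlier step is a 1.2-fold lower number from compound 1 to compound 2 (0.07 log units; within the scatter), the same change on the core of compound 3 is expected to stay within the scatter as well. Compound 4 is therefore expected to give about 11000 nM in this assay, with a step estimated as a 1.2-fold lower number from compound 3 to compound 4 (0.07 log units; within the scatter). This estimate rests on two compounds only, and a range from 6000 nM to 22000 nM is expected for compound 4.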

Compound 4, half-maximal inhibitory concentration: 13600 nM
Beside the measured number, compound 4's estimate is 1.2-fold (0.09 log units) below it, and the stated range covers the measured number.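

In this assay, putting nitro in place of hydroxy on the core of compound 3 gives a 1.1-fold higher number from compound 3 to compound 4 (0.03 log units; within the scatter), so the two numbers cannot be told apart. The same change on the core of compound 1 also stayed within the scatter, and the two steps agree with each other, so in this small set the change reads the same on both cores: the same change on two cores in this assay, a 1.2-fold lower number (0.07 log units; within the scatter) from compound 1 to compound 2 and a 1.1-fold higher number (0.03 log units; within the scatter) from compound 3 to compound 4, 1.3-fold (0.10 log units) apart, within the scatter of two such steps

Among these compounds, this shows only that a swap with no measurable effect on one core also has none on the other; it does not show that a change with a clear effect would carry over between cores in the same way, and two cores are too few to support a rule for the wider series.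

The compounds shown leave open whether a different group on this aromatic carbon, such as an amine or a carboxylic acid, would move the number beyond the scatter on either core. On these data alone, compound 1 and compound 3 also differ from each other in more than one place, and what each of those differences contributes remains unknown.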